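Methoxyphenyl in place of fluorophenyl on the alkyne

This account rests on a few compounds, and the source may have more. Where it says the series, first, only, none or still open, it means among the compounds named here.

compound 1 `COC(=O)c1sc2cc(C#Cc3ccccc3F)cnc2c1N`: > 150000 nM
compound 2 `COC(=O)c1sc2cc(C#Cc3ccc(N(C)C)cc3)cnc2c1N`: 20600 nM

In a functional assay on MCF7 cells (Homo sapiens) for inhibition, read by sulforhodamine B assay, with a stated time of 48 h (on this read-out higher numbers stand for weaker inhibition of growth and lower numbers for stronger inhibition of growth), compound 1 gives only a limit, > 150000 nM, as recorded in the limit of > 150000 nM in this assay, at which 1 of the 2 values shown sits. Compound 2 gives 20600 nM in this assay. Compound 3 `COC(=O)c1sc2cc(C#Cc3cccc(OC)c3)cnc2c1N` carries 3-methoxyphenyl in place of 2-fluorophenyl on a triple-bonded carbon. Going by the values given here, compound 1 offers no number to step from, so no measured step exists; in this assay a gain beyond the scatter is expected from this change, since compound 2 with its substituted phenyl reaches 20600 nM. Compound 3 is therefore expected at 60000 nM, in the range 15000 nM to 200000 nM. The expected step is an at least 2.5-fold lower number from compound 1 to compound 3 (0.39 log units; beyond the scatter).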

Compound 3, concentration for 50% growth inhibition: 33400 nM
Compound 3: the middle estimate sits 1.8-fold (0.25 log units) above what was measured; the range from low to high includes it.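

In this assay, going by these compounds alone, 3-methoxyphenyl in place of 2-fluorophenyl on a triple-bonded carbon gives the first step that can be read at this position, an at least 4.4-fold lower number from compound 1 to compound 3 (0.65 log units; beyond the scatter). The entering group carries oxygen where the leaving group carries fluorine, and both keep the six-membered aromatic ring of carbon only. The step has only a lower bound, since compound 1 is known solely by a limit: the limit of > 150000 nM in this assay, at which 1 of the 3 values shown sits.

The compounds shown leave open whether losing the fluorine or gaining the methoxy group carries this step. They also leave open how an unsubstituted phenyl, a 3-hydroxyphenyl or a 3-aminophenyl behaves on the same triple-bonded carbon.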